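Ester, Amide and Acid on a Shared Indole Core

The source may hold more compounds than are shown below. What is called first, only, known or untested is meant among the compounds shown, and "the series" means these compounds.

Measured so far in an assay on a protein complex for inhibition of CDK8/Cyclin C (Homo sapiens), with a stated time of 1 h; on this read-out higher numbers stand for weaker inhibition and lower numbers for stronger inhibition:
- compound 1, `CCOC(=O)/C=C/c1ccncc1-c1ccc2[nH]ccc2c1`: 107 nM
- compound 2, `Cn1ccc2cc(-c3cnccc3/C=C/C(=O)O)ccc21`: 26.8 nM
- compound 3, `CNC(=O)/C=C/c1ccncc1-c1ccc2[nH]ccc2c1`: 51.9 nM

Compound 3 stands second highest of the three numbers. Its nearest neighbour is compound 2, whose value lies within the scatter of it, and its furthest is compound 1, whose value lies beyond the scatter.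

Compound 4, `O=C(O)/C=C/c1ccncc1-c1ccc2[nH]ccc2c1`, has not been measured. It differs from compound 3 in one place: hydroxy in place of methylamino on a carbonyl carbon. Cut one bond further out, this is methylcarbamoyl going to carboxy.

Within the data shown here, only one measured step bears on the carbonyl substituent: a 2.1-fold lower number from compound 1 to compound 3 (0.31 log units; beyond the scatter). Among the measured compounds shown here, the step from ethoxy to methylamino gave a modest gain, so a second change at the same carbon may move the number a little further, though no measured pair shows methylamino against hydroxy directly. Compound 2, which carries the carboxy group on a related core, gives 26.8 nM.

Compound 4 is therefore expected to come in near 32 nM, a step of a 1.6-fold lower number from compound 3 to compound 4 (0.21 log units; within the scatter), within 13 nM to 80 nM.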

Compound 4, half-maximal inhibitory concentration: 17 nM
Beside the measured number, compound 4's estimate is 1.9-fold (0.27 log units) above it; measured number inside the range.
By their numbers in this assay, from the lowest: compounds 4, 2 and 3 (each within the scatter of the next, the first and the last beyond it); then compound 1.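

In this assay, the carbonyl carbon turns out to respond clearly to what it carries: hydroxy in place of methylamino gives a 3.1-fold lower number from compound 3 to compound 4 (0.48 log units; beyond the scatter), and hydroxy in place of ethoxy, read as hydrogen in place of ethyl on the oxygen, gives a 6.3-fold lower number from compound 1 to compound 4 (0.80 log units; beyond the scatter), both beyond the scatter. With the carboxy group in place, hydrogen in place of methyl on the aromatic nitrogen gives a 1.6-fold lower number from compound 2 to compound 4 (0.20 log units; within the scatter), which is within the scatter, so this read-out cannot separate these two acids. No data shown here give a reason for these steps.

The compounds shown do not tell how a primary amide or a hydroxamic acid would read on this carbonyl carbon. They also leave open whether a longer chain in place of 2-carboxyethenyl would keep the lower number.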